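Two cores, one methyl-to-methoxy swap

This account rests on a few compounds, and the source may have more. Where it says the series, first, only, none or still open, it means among the compounds named here.

Measured so far:
compound 1, `Cc1ccc2c(c1)N(S(=O)(=O)c1ccc(-c3cnc(C4CC4)o3)cc1)CCCO2`, 29 nM
compound 2, `Cc1ccc2c(c1)OCCCN2S(=O)(=O)c1ccc(-c2cnc(C3CC3)o2)cc1`, 766 nM
compound 3, `COc1ccc2c(c1)N(S(=O)(=O)c1ccc(-c3cnc(C4CC4)o3)cc1)CCCO2`, 47 nM

All three were tested in a functional assay on HCT-116 cells (Homo sapiens) for antiproliferative activity, read by MTT assay, with a stated time of 72 h; on this read-out lower numbers stand for stronger inhibition and higher numbers for weaker inhibition. Compound 1 and compound 2 are built from the same atoms joined differently; the difference between the two cores is not broken down here, but compound 2 gives a much higher number than compound 1, and the gap to compound 3 is also beyond the usual scatter. Compound 3 carries a methoxy where compound 1 carries a methyl, the change (methoxy in place of methyl on an aromatic carbon); the step of a 1.6-fold higher number from compound 1 to compound 3 (0.21 log units; within the scatter) is small and within the scatter.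

Compound 4, `COc1ccc2c(c1)OCCCN2S(=O)(=O)c1ccc(-c2cnc(C3CC3)o2)cc1`, is not yet measured. It differs from compound 2 by methoxy in place of methyl on an aromatic carbon, the same change seen from compound 1 to compound 3, at a place described in the same words. On that one example, the step of a 1.6-fold higher number from compound 2 to compound 4 (0.19 log units; within the scatter) is expected to be about as small, because compound 3 moved from compound 1 by only a 1.6-fold higher number from compound 1 to compound 3 (0.21 log units; within the scatter). Compound 4 is therefore estimated at 1200 nM, likely between 400 nM and 3500 nM.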

Compound 4, half-maximal inhibitory concentration: 223 nM
Compound 4: the middle estimate sits 5.4-fold (0.73 log units) above what was measured, outside the stated range (below it).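

In this assay, putting methoxy in place of methyl on the core of compound 2 gives a 3.4-fold lower number from compound 2 to compound 4 (0.54 log units; beyond the scatter), a modest step but a real one. The same change therefore does not carry over from one core to the other with the same size: the same change on two cores in this assay, a 1.6-fold higher number (0.21 log units; within the scatter) from compound 1 to compound 3 and a 3.4-fold lower number (0.54 log units; beyond the scatter) from compound 2 to compound 4, 5.6-fold (0.75 log units) apart, beyond the scatter of two such steps. A result for this swap on one core cannot simply be copied to the other, although these two pairs do not show why the cores respond differently, or whether any other change would differ between them in the same way.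

The compounds shown compare only methyl and methoxy at this place on the two cores, so a single pair of groups carries the whole comparison. On these data alone, it remains open whether a hydroxyl, an amine or a longer chain such as ethoxy would also give different steps on the two cores, or would give matching ones.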